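A few compounds are considered here, and "the series" means these few. Any claim that something is new, unique, unknown or untested is made for them only; others in the source may bear on it.

Compound 1 `C=CCONC(=O)CN1C(=O)S/C(=C\c2ccc(C(F)(F)F)cc2)C1=O` is the starting point. In an ADME assay on RAW264.7 cells (Mus musculus) for cytotoxicity, read by neutral red uptake, with a stated time of 24 h (a lower number here means that less compound is tolerated, a higher number that more compound is tolerated), compound 1 gives > 128000 nM, which is a limit of the assay rather than a measured number. Compound 2 `C=CCONC(=O)C(C)N1C(=O)S/C(=C\c2ccc(C(F)(F)F)cc2)C1=O` differs from compound 1 by a single change, (methyl in place of hydrogen on a saturated chain carbon bound to an amide-type nitrogen in a ring and a carbonyl carbon). In this assay compound 2 gives > 128000 nM, again a limit of the assay. The step that the two limits leave unreadable from compound 1 to compound 2 cannot be sized because the limit of > 128000 nM in this assay, at which 3 of the 3 values shown sit, is where both values sit.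

Compound 3 `O=C(CN1C(=O)S/C(=C\c2ccc(F)cc2)C1=O)NOCc1ccccc1` is built on a different core; the difference between the two cores is not broken down here. In this assay compound 3 gives > 128000 nM, once more a limit of the assay.

Compound 4 `CC(C(=O)NOCc1ccccc1)N1C(=O)S/C(=C\c2ccc(F)cc2)C1=O` has not yet been measured. Among the measured compounds shown here, it differs from compound 3 by methyl in place of hydrogen on a saturated chain carbon bound to an amide-type nitrogen in a ring and a carbonyl carbon, the same change as the one between compound 1 and compound 2. For the measured compounds named here, nothing seen so far reads as a real change in tolerance: every value recorded in this assay sits at a limit, so the only prior example of this change gives no direction at all. The expected step is a step that the limit leaves unreadable from compound 3 to compound 4, an expectation that rests on the unreadable step that the two limits leave unreadable from compound 1 to compound 2 and on (the limit of > 128000 nM in this assay, at which 3 of the 3 values shown sit). Compound 4 is estimated at about 200000 nM, with a range from 100000 nM to 500000 nM, and it is expected that the assay will most likely once more report only a limit.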

Compound 4, half-maximal cytotoxic concentration: > 128000 nM
Compound 4 gave a limit, no number; the forecaster's own chance of this, stated with the estimate: 90%; the middle value is on the limit's open side.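

In this assay compound 4 gives > 128000 nM, which is a limit of the assay rather than a measured number. The change from compound 3 to compound 4 therefore has no readable size: the limit of > 128000 nM in this assay, at which 4 of the 4 values shown sit.

The compounds shown leave open what concentration actually harms these cells, and whether methyl in place of hydrogen at this place alters that concentration at all.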